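The source may report more compounds than this note shows. Statements on the series, on what has been measured and on what is new or still open speak of the compounds shown alone.

Measured so far in a functional assay for antagonist activity at corticotropin-releasing factor receptor 1 (Rattus norvegicus); on this read-out higher numbers stand for weaker inhibition and lower numbers for stronger inhibition:
- compound 1, `CC[C@@H](C1CC1)n1c(=O)c(C)nc2c(-c3ccc(Cl)cc3Cl)ccnc21`, 7.4 nM
- compound 2, `CC[C@@H](COC)n1c(=O)c(C)nc2c(-c3ccc(Cl)cc3Cl)ccnc21`, 74 nM
- compound 3, `CC[C@H](COC)n1c(=O)c(C)nc2c(-c3ccc(Cl)cc3Cl)ccnc21`, 4 nM

Compound 3 stands at the lowest number of the three; compound 1 sits within the scatter of it, compound 2 well beyond. The step from compound 1 to compound 3 is small (a 1.9-fold lower number from compound 1 to compound 3 (0.27 log units; within the scatter)), whereas a 19-fold lower number from compound 2 to compound 3 (1.27 log units; beyond the scatter) is large, this pair being separable only on (the fact that compounds 2 and 3 differ only in the configuration as drawn). a 10-fold higher number from compound 1 to compound 2 (1.00 log units; beyond the scatter) marks the other branch of that change.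

Compound 4, `Cc1nc2c(-c3ccc(Cl)cc3Cl)ccnc2n(C(C)C(C)C)c1=O`, carries 1,2-dimethylpropyl in place of 1-(methoxymethyl)propyl on an aromatic nitrogen. No defined stereocentre enters. Going by the values given here, the nearest measured step is the one from compound 1 to compound 3, which lay within the scatter; the stereochemical step is the only large one and cannot be read across. A small upward step is expected, a 3.0-fold higher number from compound 3 to compound 4 (0.48 log units; beyond the scatter). Compound 4 is estimated at 12 nM in this assay, within 3 nM to 45 nM.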

Compound 4, half-maximal inhibitory concentration: 380 nM
Compound 4: middle estimate off by 32-fold (1.50 log units), on the low side; measured number outside the range, above it.
By their numbers in this assay, from the lowest: compounds 3 and 1 (each within the scatter of the next); then compound 2; then compound 4.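

The 1,2-dimethylpropyl chain on this aromatic nitrogen gives the highest number in the series, with a 95-fold higher number from compound 3 to compound 4 (1.98 log units; beyond the scatter) and a 51-fold higher number from compound 1 to compound 4 (1.71 log units; beyond the scatter) and even a 5.1-fold higher number from compound 2 to compound 4 (0.71 log units; beyond the scatter) as the steps to it. The chain is therefore far from interchangeable here, and losing the oxygen does not explain this alone, since compound 1 also has no oxygen in that chain. With no defined stereocentre, compound 4 cannot be matched to either side of the pair that already spreads widely: (the fact that compounds 2 and 3 differ only in the configuration as drawn).

On these data alone, how each configuration of the 1,2-dimethylpropyl chain would read stays open. So does whether a 1-ethylpropyl group or a chain ending in an amine would sit nearer compound 3 or compound 4.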